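A few compounds are considered here, and "the series" means these few. Any claim that something is new, unique, unknown or untested is made for them only; others in the source may bear on it.

Compound 1 `CC(C)CN(Cc1cn2c(N3CCN(C)CC3)cccc2n1)[C@H]1CCCc2cccnc21` was tested in an ADME assay on HOS cells (Homo sapiens) for cytotoxicity (a higher number here means that more compound is tolerated, a lower number that less compound is tolerated), where compound 1 gives 20000 nM. That is the highest of the two numbers in this assay; compound 3 `CN(C)[C@H]1CCN(c2cccc3nc(CN(C)[C@H]4CCCc5cccnc54)cn23)C1` gives 2100 nM, a lower number beyond the scatter. For compound 2 `CN1CCN(c2cccc3nc(CN(C)[C@H]4CCCc5cccnc54)[nH]c23)CC1` the assay reports only a limit, > 5000 nM, which is the limit of > 5000 nM in this assay, at which 1 of the 3 values shown sits. Compound 4 `CN1CCN(c2cccc3nc(CN(Cc4ccccc4)[C@H]4CCCc5cccnc54)cn23)CC1` differs from compound 1 by phenyl in place of isopropyl on a saturated chain carbon bound to an amine nitrogen. Among the measured compounds shown here, no measured pair in this set carries that change, so only a modest step is expected, if any, with compound 4 perhaps tolerated slightly less than compound 1. Compound 4 is therefore estimated at 15000 nM, between 5000 nM and 40000 nM, which would mean an expected step of a 1.3-fold lower number from compound 1 to compound 4 (0.12 log units; within the scatter).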

Compound 4, half-maximal cytotoxic concentration: 9300 nM
Beside the measured number, compound 4's estimate is 1.6-fold (0.21 log units) above it; low and high end bracket the measured number.
By their numbers in this assay, from the lowest: compound 3; then compound 4; then compound 1.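

In this assay, among the compounds shown here, the exchange of phenyl for isopropyl gives the first step that can be read at this position, on a saturated chain carbon bound to an amine nitrogen: a 2.2-fold lower number from compound 1 to compound 4 (0.33 log units; beyond the scatter). The number therefore responds to this change, though only modestly. The data shown give no cause for this step.

As far as these compounds go, whether the step follows from the aromatic ring itself or from the larger group remains open. So does what a cyclohexyl ring, a longer chain or a benzyl carrying an amine would do here.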